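Lengthening the Sulfur-Bound Chain from Compound 2 to Compound 3

A few compounds are considered here, and "the series" means these few. Any claim that something is new, unique, unknown or untested is made for them only; others in the source may bear on it.

Compound 2 `CCSc1nnc(Cc2ccc(Cl)cc2Oc2ccccc2F)[nH]1` gives 141% in a functional assay on the whole organism (strain NMRI) with Mus musculus as the target, with a stated time of 60 min, at a dose of 20 mg/kg by the intraperitoneal route; on this read-out higher numbers stand for a stronger effect at the one dose given and lower numbers for a weaker effect. For the measured compounds named here, the only other compound measured, compound 1 `CSc1nnc(Cc2ccc(Cl)cc2Oc2ccccc2F)[nH]1`, gives 136% in this assay, and the two numbers lie within the scatter of each other, so neither can be called the more active. Compound 3 `CCCSc1nnc(Cc2ccc(Cl)cc2Oc2ccccc2F)[nH]1` has not yet been measured in this assay. It differs from compound 2 by methyl in place of hydrogen on a saturated chain carbon, two bonds along the chain from a sulfur, so that the ethylsulfanyl group becomes a propylsulfanyl group. Going by the values given here, one measured step bears on this: a number 5 percentage points higher from compound 1 to compound 2 (within the scatter), which is itself the addition of one carbon to the chain on sulfur and stayed within the scatter. Because a number 5 percentage points higher from compound 1 to compound 2 (within the scatter) produced no change beyond the scatter, compound 3 is expected to sit close to compound 2, with the estimated step of a number 1 percentage points lower from compound 2 to compound 3 (within the scatter). The estimate for compound 3 in this assay is 140%, with a range from 120% to 160%.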

Compound 3, a percentage reported as activity, at one dose (the size of the read-out at that dose, not a potency): 133%
Beside the measured number, compound 3's estimate is 7 percentage points above it, within the range that was stated.
By their numbers in this assay, from the lowest: compounds 3, 1 and 2 (each within the scatter of the next).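

In this assay a second lengthening of the chain on sulfur can now be read: the change from ethylsulfanyl to propylsulfanyl gives a number 8 percentage points lower from compound 2 to compound 3 (within the scatter), and the wider change from the shortest chain gives a number 3 percentage points lower from compound 1 to compound 3 (within the scatter). Where the earlier pair covered a single added carbon, these steps show that neither one added carbon nor two on the chain bound to sulfur moves the number beyond the scatter at this one dose. Nothing measured here bears on why the numbers stay so close.

Still open, on these data alone, is whether a longer chain such as butyl, or a branched isopropyl group on sulfur, would stay within the same band, and whether a chain carrying an amine or a carboxylic acid would leave it. The read-out, taken at one dose, also says nothing of potency.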